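Fluoro to Chloro on the Triazole-Borne Phenyl Ring

The source may hold more compounds than are shown below. What is called first, only, known or untested is meant among the compounds shown, and "the series" means these compounds.

Compound 1 `Cc1ccccc1-n1nncc1CN1C(=O)C2(C(C#N)=C(N)Oc3c(N)cc4nc5ccccc5nc4c32)c2ccccc21`, in a functional assay on HCT-116 cells (Homo sapiens) for antiproliferative activity, read by MTT assay, with a stated time of 48 h (on this read-out higher numbers stand for weaker inhibition and lower numbers for stronger inhibition), compound 1 gives a limit only, > 50000 nM.
Compound 2 `CCc1ccccc1-n1nncc1CN1C(=O)C2(C(C#N)=C(N)Oc3c(N)cc4nc5ccccc5nc4c32)c2ccccc21`, in this assay compound 2 gives 10300 nM.
Compound 3 `N#CC1=C(N)Oc2c(N)cc3nc4ccccc4nc3c2C12C(=O)N(Cc1cnnn1-c1ccc(F)cc1)c1ccccc12`, in this assay compound 3 gives a limit only, > 50000 nM.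

Of the three measured compounds, only compound 2 returns a number in this assay; compound 1 and compound 3 both sit at the limit (the limit of > 50000 nM in this assay, at which 2 of the 3 values shown sit). Compound 3 thus stands at the weak end of what is shown, and the single readable step that reaches it, an at least 4.8-fold higher number from compound 2 to compound 3 (0.68 log units; beyond the scatter), runs toward weaker inhibition. The step that the two limits leave unreadable from compound 1 to compound 3 cannot be read, and the step of an at least 4.8-fold lower number from compound 1 to compound 2 (0.68 log units; beyond the scatter) concerns a chain on the other aromatic ring.

Compound 4 `N#CC1=C(N)Oc2c(N)cc3nc4ccccc4nc3c2C12C(=O)N(Cc1cnnn1-c1ccc(Cl)cc1)c1ccccc12` differs from compound 3 by chloro in place of fluoro on an aromatic carbon. No measured step touches a halogen on this ring, so nothing among the shown compounds speaks for a move away from the limit. Compound 3 gives only a limit, > 50000 nM, which leaves even the starting point open. Compound 4 is therefore expected to stay near that limit, with the step that the limit leaves unreadable from compound 3 to compound 4 estimated as none beyond the scatter, and the estimate for compound 4 in this assay is 60000 nM, between 15000 nM and 200000 nM.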

Compound 4, half-maximal inhibitory concentration: > 50000 nM
Compound 4 was reported as a limit; the forecaster's own chance of this, stated with the estimate: 65%; the middle value does not contradict the limit.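

In this assay compound 4 gives > 50000 nM, which is a limit of the assay and not a number. Among the compounds shown here, with chloro as with fluoro at this place, para to a large group, the compound sits at the limit, so neither halogen gives a readable value, and the one step that can be read, an at least 4.8-fold higher number from compound 2 to compound 4 (0.68 log units; beyond the scatter), runs toward weaker inhibition, as the step from compound 2 to compound 3 does. The steps among compound 1, compound 3 and compound 4 cannot be read, and the limit now accounts for most of what is shown: the limit of > 50000 nM in this assay, at which 3 of the 4 values shown sit.

How far apart compound 3 and compound 4 lie beyond the limit stays open, so nothing shown separates chloro from fluoro at this place. Also open, going by these compounds, is whether a methoxy group or an amine at this place would bring a value back into the readable range, and whether a longer chain in place of the ethyl group of compound 2 would give stronger inhibition than that compound.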